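A few compounds are considered here, and "the series" means these few. Any claim that something is new, unique, unknown or untested is made for them only; others in the source may bear on it.

Measured so far in a functional assay on cells (Macrophage, Mus musculus) for activation; on this read-out higher numbers stand for an effect only at larger amounts of compound and lower numbers for an effect already at smaller amounts:
- compound 1 `CCCCCCCCCCCC(=O)O[C@H](CCCCCCCCCCC)CC(=O)NC(CCOP(=O)(O)O)C(=O)NCCC[C@H](COP(=O)(O)O)NC(=O)C[C@H](O)CCCCCCCCCCC`: 0.083 ug/mL
- compound 2 `CCCCCCCCCCCC(=O)O[C@H](CCCCCCCCCCC)CC(=O)N[C@H](CCOP(=O)(O)O)C(=O)NCCC[C@H](CO)NC(=O)C[C@H](O)CCCCCCCCCCC`: 1.85 ug/mL

Compound 2 holds the highest of the two numbers; its nearest neighbour, compound 1, sits at a lower value, and that gap lies beyond the usual scatter. Within the data shown here, no single-point step between the two measured compounds can be drawn, as they differ in more than one place, so their values are only recorded side by side.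

Compound 3 `CCCCCCCCCCCC(=O)O[C@H](CCCCCCCCCCC)CC(=O)NC(CCOP(=O)(O)O)C(=O)NCCC[C@H](CO)NC(=O)C[C@H](O)CCCCCCCCCCC` is not yet measured. Against compound 2 it differs as follows: the two compounds have the same atoms and bonds; at least one stereo element is drawn with a configuration in one of them and without one in the other: 1 of 4 stereo elements differ; a stereocentre at a saturated chain carbon is drawn R in compound 2 and without a configuration in compound 3. The atoms and bonds are the same; only the drawn configuration at one stereocentre is absent. Among the measured compounds shown here, with no measured pair that isolates such a change, no directional step is expected beyond the scatter for no change at the digits printed from compound 2 to compound 3 (within the scatter). Compound 3 is therefore expected to give about 1.85 ug/mL in this assay, with a range from 0.8 ug/mL to 4.5 ug/mL.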

Compound 3, half-maximal effective concentration: 3.53 ug/mL
For compound 3 the middle estimate is 1.9-fold (0.28 log units) below the measured one; measured number inside the range.
By their numbers in this assay, from the lowest: compound 1; then compounds 2 and 3 (each within the scatter of the next).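

In this assay, among these compounds, compounds 1 and 3 give the first comparison that differs in one place: a hydrogen atom replaces the phosphate group of 4 heavy atoms (3 oxygen, 1 phosphorus) on an oxygen on a saturated carbon, with a 43-fold higher number from compound 1 to compound 3 (1.63 log units; beyond the scatter). At the stereocentre on the saturated chain carbon, the read-out gives a 1.9-fold higher number from compound 2 to compound 3 (0.28 log units; within the scatter), so dropping the drawn configuration there has no effect that can be told from the scatter. The only information on configuration at this place is limited to a defined and an undefined drawing: the fact that one of compounds 2 and 3 is drawn with a defined configuration and the other without, at the place where they differ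

From the compounds shown here alone, whether a carboxylic acid or a sulfate on the same oxygen would keep the number near that of compound 1 remains open. Also open, going by these compounds, is how a compound drawn with the opposite configuration at the stereocentre would read.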